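Chlorophenyl triazole sulfonamides: notes on an antiproliferative series

A few compounds are considered here, and "the series" means these few. Any claim that something is new, unique, unknown or untested is made for them only; others in the source may bear on it.

Measured compounds, in a functional assay on HepG2 cells (Homo sapiens) for antiproliferative activity, read by MTT assay, with a stated time of 24 h; on this read-out higher numbers stand for weaker inhibition and lower numbers for stronger inhibition:
compound 1, `O=c1[nH]cc(S(=O)(=O)Nc2cccc(-c3cn(-c4cccc(Cl)c4)nn3)c2)c(=O)[nH]1`: 4200 nM
compound 2, `O=c1[nH]cc(S(=O)(=O)Nc2cccc(-c3cn(-c4ccc(Cl)cc4)nn3)c2)c(=O)[nH]1`: 1960 nM
compound 3, `O=c1[nH]cc(S(=O)(=O)Nc2ccc(-c3cn(-c4cccc(Cl)c4)nn3)cc2)c(=O)[nH]1`: 2020 nM

Compound 1 and compound 2 share one core and differ in a single place: 4-chlorophenyl in place of 3-chlorophenyl on an aromatic nitrogen. This change gave a 2.1-fold lower number from compound 1 to compound 2 (0.33 log units; beyond the scatter) in this assay. Compound 3 carries a different core; how the core of compound 3 differs from the core of compound 1 is not broken down here, and the two values of compound 1 and compound 3 simply show a higher number for compound 1 and a lower one for compound 3. Compound 2 and compound 3 give numbers that lie within the scatter of each other, so no order between them is drawn.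

Compound 4, `O=c1[nH]cc(S(=O)(=O)Nc2ccc(-c3cn(-c4ccc(Cl)cc4)nn3)cc2)c(=O)[nH]1`, has not yet been measured. It stands to compound 3 as compound 2 stands to compound 1: 4-chlorophenyl in place of 3-chlorophenyl on an aromatic nitrogen. The change in the two pairs is the same, at the same place by every word of its description, and occurs twice in all among the four compounds.

Among the compounds with values here, on the single precedent of compound 1 to compound 2, the step from compound 3 to compound 4 is expected to be about a 2.0-fold lower number from compound 3 to compound 4 (0.31 log units; beyond the scatter), because the same change gave a 2.1-fold lower number from compound 1 to compound 2 (0.33 log units; beyond the scatter). The estimate for compound 4 in this assay is therefore 1000 nM, with a range of 500 nM to 2400 nM; this expectation rests on one pair only, and the core of compound 3 is a different one, so the range is kept wide.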

Compound 4, half-maximal inhibitory concentration: 1980 nM
Compound 4: the middle estimate sits 2.0-fold (0.30 log units) below what was measured; the measured number falls inside the stated range.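

In this assay, within the data shown here, 4-chlorophenyl in place of 3-chlorophenyl on an aromatic nitrogen gives a 1.0-fold lower number from compound 3 to compound 4 (0.01 log units; within the scatter), so on the core of compound 3 this change produces no step that can be read apart from the scatter of repeated measurements. Set beside the step on the core of compound 1, the new step cannot be called different: the same change on two cores in this assay, a 2.1-fold lower number (0.33 log units; beyond the scatter) from compound 1 to compound 2 and a 1.0-fold lower number (0.01 log units; within the scatter) from compound 3 to compound 4, 2.1-fold (0.32 log units) apart, within the scatter of two such steps. The data therefore give no firm sign that the change behaves differently on the two cores, but they do not show that it carries over either, as one step lies beyond the scatter, the other lies within it, and two pairs are too few to settle the matter.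

The compounds shown leave open whether any step would appear with a group other than chlorine on the phenyl ring, such as methoxy, an amine or a carboxylic acid, and whether a longer chain in place of that ring would fit the same picture. They also leave open whether the two steps would stay this close on a third core, or in any read-out other than this assay.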